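A Methyl Step Repeated on a Second Core

The source may hold more compounds than are shown below. What is called first, only, known or untested is meant among the compounds shown, and "the series" means these compounds.

Compound 1 `Nc1nc(N)c2cc(NC(=O)CCc3ccc(Cl)cc3)ccc2n1` and compound 3 `Cc1c(NC(=O)CCc2ccc(Cl)cc2)ccc2nc(N)nc(N)c12` share one core and differ in a single place, (methyl in place of hydrogen on an aromatic carbon). In an assay for inhibition of Dihydrofolate reductase (Homo sapiens) (on this read-out higher numbers stand for higher potency (the scale is a negative logarithm) and lower numbers for lower potency), compound 1 gives 7.33, and compound 3 gives 7.48, so that a number 0.15 log units higher from compound 1 to compound 3 (within the scatter).

Compound 2 `CCOC(=O)CC[C@H](NC(=O)c1ccc(CNc2ccc3nc(N)nc(O)c3c2)cc1)C(=O)OCC` is built on a different core, and the difference between the two cores is not broken down here. In this assay compound 2 gives 6.24, the lowest of the three numbers; the gaps to compound 1 and to compound 3 both lie beyond the scatter.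

Compound 4 `CCOC(=O)CC[C@H](NC(=O)c1ccc(CNc2ccc3nc(N)nc(O)c3c2C)cc1)C(=O)OCC` has not yet been measured. It differs from compound 2 by methyl in place of hydrogen on an aromatic carbon, and the surroundings of the place match those of the earlier change word for word, so the same change is made a second time.

Among the compounds with values here, what is expected for compound 4 rests on the single earlier step: because a number 0.15 log units higher from compound 1 to compound 3 (within the scatter), the step of a number 0.16 log units higher from compound 2 to compound 4 (within the scatter) is estimated to be small as well. On that basis compound 4 is expected to give 6.4, with a range from 5.9 to 6.9.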

Compound 4, logarithm of the reciprocal of the active concentration, log(1/C): 5.57
For compound 4 the middle estimate is 0.83 log units above the measured one; measured number below the stated range.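

On the second core, methyl in place of hydrogen on an aromatic carbon gives a number 0.67 log units lower from compound 2 to compound 4 (beyond the scatter). Set beside the earlier step in this assay, the same change does not keep its size from one core to the other: the same change on two cores in this assay, a number 0.15 log units higher (within the scatter) from compound 1 to compound 3 and a number 0.67 log units lower (beyond the scatter) from compound 2 to compound 4, 0.82 log units apart, beyond the scatter of two such steps This shows that, across these two pairs, the outcome of the methyl change differs with the core that carries it, so the step on the core of compound 1 was no safe guide to the step on the core of compound 2; it does not show which feature of the two cores accounts for the gap, and with only one pair on each core it gives no rule for any further core.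

The compounds shown leave open whether an ethyl group or a chlorine at the same place would behave like the methyl on either core. They also leave open whether the step from hydrogen to methyl would hold with carboxylic acids in place of the ethyl esters of compound 2.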